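The compounds below may be only part of what the source reports. "The series", "measured", "known", "first", "only" and "open" are said of these compounds alone.

Compound 2, `CCCCC[C@H](c1ccc(C(=O)NCc2nn[nH]n2)cc1)N1C(=O)C(c2cc(Cl)cc(Cl)c2)=N[C@]12CC[C@@H](C(C)(C)C)CC2`, stands lowest of the two numbers in a functional assay on CHO cells for antagonist activity at Glucagon receptor (Homo sapiens), read by cAMP accumulation, with stated times of 30 min and 45 min (a higher number here means a weaker inhibitor, a lower number a stronger inhibitor), where compound 2 gives 130 nM; compound 1, `CCC[C@H](c1ccc(C(=O)NCc2nn[nH]n2)cc1)N1C(=O)C(c2cc(Cl)cc(Cl)c2)=N[C@]12CC[C@@H](C(C)(C)C)CC2`, gives 220 nM in this assay, and the step of a 1.7-fold lower number from compound 1 to compound 2 (0.23 log units; within the scatter) is the only one measured so far. Compound 3, `CC(C)CC[C@H](c1ccc(C(=O)NCc2nn[nH]n2)cc1)N1C(=O)C(c2cc(Cl)cc(Cl)c2)=N[C@]12CC[C@@H](C(C)(C)C)CC2`, differs from compound 2 by isopropyl in place of propyl on a saturated chain carbon, three bonds along the chain from an amide-type nitrogen in a ring and an aromatic carbon. Going by the values given here, the one measured step bears on it only loosely: it lengthened the chain on the same carbon and moved the number within the scatter, whereas the change to compound 3 keeps the same atoms and only branches the chain. With nothing in the data pointing to a change beyond the scatter, compound 3 is expected to sit close to compound 2 in this assay, the expected step being no change at the digits printed from compound 2 to compound 3 (within the scatter). Compound 3 is therefore estimated at 130 nM, with a range from 60 nM to 300 nM.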

Compound 3, half-maximal inhibitory concentration: 150 nM
Estimate against measurement, compound 3: 1.2-fold (0.06 log units) below; the measured number falls inside the stated range.
By their numbers in this assay, from the lowest: compounds 2, 3 and 1 (each within the scatter of the next).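

Branching the chain at this place, on a saturated chain carbon, three bonds along the chain from an amide-type nitrogen in a ring and an aromatic carbon, gives a 1.2-fold higher number from compound 2 to compound 3 (0.06 log units; within the scatter) in this assay, so the earlier length step now has a companion step in shape. Measured against the shorter chain, the same branched group gives a 1.5-fold lower number from compound 1 to compound 3 (0.17 log units; within the scatter) in this assay, and thus all three saturated chains shown at this carbon lie within the scatter of one another. Nothing available accounts for these numbers or shows what the chain does here.

The compounds shown leave open whether a longer chain, a cyclohexyl ring or an amine at this carbon would also stay within the scatter. They also leave open whether branching closer to this carbon, as in a tert-butyl group, would do so.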